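Ring methyl removal and tolerated concentration in the series

The source may hold more compounds than are shown below. What is called first, only, known or untested is meant among the compounds shown, and "the series" means these compounds.

In an ADME assay on MT4 cells (Homo sapiens) for cytotoxicity, read by MTT assay (a higher number here means that more compound is tolerated, a lower number that less compound is tolerated), compound 1 `N#Cc1ccc(Nc2nccc(NC3CCCCC3)n2)cc1` gives 7330 nM, compound 2 `Cc1cnc(Nc2ccc(C#N)cc2)nc1NC1CCCCC1` gives 1300 nM, and compound 3 `Cc1cc(NC2CCCC2)nc(Nc2ccc(C#N)cc2)n1` gives 310 nM. Compound 1 differs from compound 2 by hydrogen in place of methyl on an aromatic carbon, and this step is a 5.6-fold higher number from compound 2 to compound 1 (0.75 log units; beyond the scatter). Compound 3 has the lowest of the three numbers; the difference between its core and that of compound 2 is not broken down here. Compound 4 `N#Cc1ccc(Nc2nccc(NC3CCCC3)n2)cc1`, not yet measured, differs from compound 3 by hydrogen in place of methyl on an aromatic carbon. This is the same kind of change as between compound 2 and compound 1, not the same: there the methyl stood ortho to a cyclohexylamino group, two atoms from the ring nitrogen and para to a group of 9 heavy atoms; here it stands next to the ring nitrogen, meta to a cyclopentylamino group, meta to a group of 9 heavy atoms and opposite the ring nitrogen. Because a 5.6-fold higher number from compound 2 to compound 1 (0.75 log units; beyond the scatter), a rise is expected in this assay, tempered by the different surroundings, and the estimated step is a 3.2-fold higher number from compound 3 to compound 4 (0.51 log units; beyond the scatter). Compound 4 is therefore expected to give about 1000 nM, between 400 nM and 3000 nM.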

Compound 4, half-maximal cytotoxic concentration: 9130 nM
The estimate for compound 4 lay 9.1-fold (0.96 log units) below the measured number, outside the stated range (above it).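

In this assay, hydrogen in place of methyl on an aromatic carbon gives a 29-fold higher number from compound 3 to compound 4 (1.47 log units; beyond the scatter), and beside the earlier step the direction repeats but the size does not carry over: the same change on two cores in this assay, a 5.6-fold higher number (0.75 log units; beyond the scatter) from compound 2 to compound 1 and a 29-fold higher number (1.47 log units; beyond the scatter) from compound 3 to compound 4, 5.2-fold (0.72 log units) apart, beyond the scatter of two such steps

A rise can therefore be read across these two pairs, but the step on one core does not set the step on the other, and two pairs establish no rule for the series. Without the methyl, cyclopentyl in place of cyclohexyl gives a 1.2-fold higher number from compound 1 to compound 4 (0.10 log units; within the scatter), yet the methyl stands at a different place in each pair, and these compounds do not show why the steps differ.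

Left open is whether ethyl or chlorine on the same aromatic carbons follows methyl. On these data alone, a longer open chain in place of cyclopentyl also remains untested here.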